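Trifluoromethylphenyl in place of fluorophenyl on a guanidine agonist

This account rests on a few compounds, and the source may have more. Where it says the series, first, only, none or still open, it means among the compounds named here.

Measured so far:
compound 1 `COc1ccc(C(CC/N=C(\N)NCCCc2c[nH]cn2)c2ccccn2)cc1` — 7.44
compound 2 `N=C(NCCCc1c[nH]cn1)NCCC(c1ccc(F)cc1)c1ccccn1` — 8.01

In a functional assay on cardiac atrium for agonist activity at histamine H2 receptor (Cavia porcellus) (a higher number here means a more potent compound, by a factor of ten per unit of this negative logarithm, a lower number a less potent compound), compound 2 gives 8.01, the higher of the two numbers obtained; compound 1 gives 7.44 in this assay, a difference beyond the usual scatter. No change between two measured compounds has been worked out here, so the move to compound 3 `N=C(NCCCc1c[nH]cn1)NCCC(c1cccc(C(F)(F)F)c1)c1ccccn1` rests on the structures alone: 3-(trifluoromethyl)phenyl in place of 4-fluorophenyl on a saturated chain carbon bound to an aromatic carbon and a saturated chain carbon. How such an exchange shifts this assay is not shown by any measured pair, and the two aryl groups are of a different kind from the one that separates compound 1 from compound 2. The step from compound 2 to compound 3 is therefore expected to be small, a number 0.11 log units lower from compound 2 to compound 3 (within the scatter), within or close to the scatter, with a wide range around it. Compound 3 is estimated at 7.9 in this assay, between 7.3 and 8.5.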

Compound 3, negative logarithm of the half-maximal effective concentration: 7.43
Compound 3: middle estimate off by 0.47 log units, on the high side, within the range that was stated.
By their numbers in this assay, from the lowest: compounds 3 and 1 (each within the scatter of the next); then compound 2.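

In this assay, within the data shown here, the first measured change at this saturated chain carbon, a number 0.58 log units lower from compound 2 to compound 3 (beyond the scatter), shows that the aryl group here is not interchangeable: 3-(trifluoromethyl)phenyl in place of 4-fluorophenyl costs potency beyond the scatter. The shared core holds the ring type, with one six-membered aromatic ring of carbon only on both sides of the step, so the loss follows the substituent on that ring and its numbered place. The value of compound 3 also lies within the scatter of that of compound 1, so this exchange leaves the 4-fluorophenyl of compound 2 alone at the top of the three. Nothing measured here accounts for the loss. On these data alone, the names 4-fluorophenyl and 3-(trifluoromethyl)phenyl differ in both substituent and number, so the two contributions remain unseparated, and how an unsubstituted phenyl or a chlorophenyl would fare at this carbon stays open.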